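Para Substituent Exchange on the Phenyl Ring

A few compounds are considered here, and "the series" means these few. Any claim that something is new, unique, unknown or untested is made for them only; others in the source may bear on it.

Compound 1, `Cn1c(-c2ccccc2)nc2c(NC3CCCCC3)ncnc21`, gives 2370 nM in an assay on CHO cells for displacement of a labelled ligand from adenosine receptor A3 (Homo sapiens), read by scintillation counting, with a stated time of 3 h; on this read-out higher numbers stand for weaker inhibition and lower numbers for stronger inhibition.
Compound 2, `Cn1c(-c2ccc(O)cc2)nc2c(NC3CCCC3)ncnc21`, gives 521 nM in this assay.

Compound 2 holds the lower of the two numbers, and compound 1 stands above it by a gap beyond the usual scatter. Compound 3, `Cn1c(-c2ccc(Cl)cc2)nc2c(NC3CCCC3)ncnc21`, differs from compound 2 by chloro in place of hydroxy on an aromatic carbon. Within the data shown here, no measured pair covers this exchange, so the expectation rests on the two values alone. In this assay this change is expected to shift the number only a little, in no clear direction, not beyond the scatter. Compound 3 is therefore estimated at 450 nM, within 120 nM to 1700 nM. This corresponds to an expected step of a 1.2-fold lower number from compound 2 to compound 3 (0.06 log units; within the scatter).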

Compound 3, inhibition constant: 1210 nM
For compound 3 the middle estimate is 2.7-fold (0.43 log units) below the measured one, and the stated range covers the measured number.
By their numbers in this assay, from the lowest: compound 2; then compounds 3 and 1 (each within the scatter of the next).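

In this assay, the exchange of 4-hydroxyphenyl for 4-chlorophenyl gives a 2.3-fold higher number from compound 2 to compound 3 (0.37 log units; beyond the scatter), so the number at this position responds to the group it carries, and the hydroxy form holds the lower number of this pair. Among these compounds, this is the first exchange here read with the rest of the molecule unchanged, as compound 1 and compound 2 differ in more than one place. Nothing at hand explains the step. Going by these compounds, whether an amine, a methoxy group or a fluoro group at this place would bring the number lower than hydroxy remains open.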